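The compounds below may be only part of what the source reports. "The series", "measured", "known", "first", "only" and "open" are said of these compounds alone.

Measured compounds:
- compound 1, `O=C(/C=C/c1ccc2c(c1)B(O)OC2)c1ccc(Cl)cc1`: in a toxicity assay on WI-38 cells (Homo sapiens) for cytotoxicity, read by MTT assay, with a stated time of 48 h (a higher number here means a weaker inhibitor, a lower number a stronger inhibitor), compound 1 gives 24700 nM
- compound 2, `O=C(/C=C/c1ccc2c(c1)B(O)OC2)c1ccc(Br)cc1`: in this assay compound 2 gives 36700 nM

Within the data shown here, compound 2 stands at the higher of the two numbers so far in this assay; its only neighbour is compound 1, and the step of a 1.5-fold higher number from compound 1 to compound 2 (0.17 log units; within the scatter) lies within the scatter, so the two compounds are not separated by these data.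

Compound 3, `CSc1ccc(C(=O)/C=C/c2ccc3c(c2)B(O)OC3)cc1`, has not yet been measured in this assay. It differs from compound 2 by methylsulfanyl in place of bromo on an aromatic carbon. Among the measured compounds shown here, the single measured step, a 1.5-fold higher number from compound 1 to compound 2 (0.17 log units; within the scatter), is a change at the same aromatic carbon from one halogen to another and bears on the new step only loosely, since methylsulfanyl is not a halogen; that step produced no movement beyond the scatter. Nothing measured in the series moves the number beyond the scatter, and the change from compound 2 to compound 3 is a small one at the same position. For compound 3 a step no larger than the scatter is therefore expected: a 1.2-fold lower number from compound 2 to compound 3 (0.09 log units; within the scatter). Compound 3 is estimated to give about 30000 nM in this assay, with a range of 12000 nM to 80000 nM.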

Compound 3, half-maximal inhibitory concentration: 54300 nM
For compound 3 the middle estimate is 1.8-fold (0.26 log units) below the measured one, within the range that was stated.
By their numbers in this assay, from the lowest: compounds 1, 2 and 3 (each within the scatter of the next, the first and the last beyond it).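

In this assay, among these compounds, methylsulfanyl is the first group other than a halogen at this aromatic carbon, and it gives a 1.5-fold higher number from compound 2 to compound 3 (0.17 log units; within the scatter), so replacing bromo does not separate the two compounds. Against chloro, the same group gives a 2.2-fold higher number from compound 1 to compound 3 (0.34 log units; beyond the scatter), the first step in the series to pass beyond the scatter, though only modestly; the position is therefore not entirely flat, with compound 3 weaker than compound 1 and compound 2 within the scatter of both. Nothing available gives a reason for this gap between compound 1 and compound 3.

From the compounds shown here alone, the separation rests on this single pair, and the three groups seen so far span only a narrow range of numbers, so it remains open whether this aromatic carbon can move the number much further. An amine, a carboxylic acid or a longer chain such as ethylsulfanyl in place of methylsulfanyl would test whether that range widens, and in which direction.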